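A few compounds are considered here, and "the series" means these few. Any claim that something is new, unique, unknown or untested is made for them only; others in the source may bear on it.

In a functional assay on HCT-15 cells (Homo sapiens) for inhibition (a higher number here means a weaker inhibitor, a lower number a stronger inhibitor), compound 2 `Oc1cccc(-c2cc(-c3cccc(OC(F)(F)F)c3)cc(-c3ccccc3O)n2)c1` gives 2740 nM, the lower of the two numbers in hand, while compound 1 `Oc1cccc(-c2cc(-c3cccc(F)c3)cc(-c3cccc(O)c3)n2)c1` gives 7860 nM in this assay. Compound 3 `Oc1cccc(-c2cc(-c3cccc(OC(F)(F)F)c3)cc(-c3cccc(O)c3)n2)c1` awaits measurement. Compound 3 differs from compound 2 in one place: 3-hydroxyphenyl in place of 2-hydroxyphenyl on an aromatic carbon. Within the data shown here, no measured pair isolates this change. Compound 1, which also carries the 3-hydroxyphenyl group, gives 7860 nM, so a shift to a higher number, beyond the scatter, is expected for compound 3. Compound 3 is therefore estimated at 5500 nM, within 2200 nM to 14000 nM, an expected step of a 2.0-fold higher number from compound 2 to compound 3 (0.30 log units; within the scatter).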

Compound 3, half-maximal inhibitory concentration: > 50000 nM
Compound 3: only a limit was reported; the forecaster's own chance of this, stated with the estimate: 5%; middle value at least 9.0-fold (0.95 log units) from the limit.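

In this assay, 3-hydroxyphenyl in place of 2-hydroxyphenyl, the same atoms joined differently, brings an at least 18-fold higher number from compound 2 to compound 3 (1.26 log units; beyond the scatter), so this position separates two otherwise matching groups sharply. With 3-hydroxyphenyl held fixed, trifluoromethoxy in place of fluoro on an aromatic carbon brings an at least 6.3-fold higher number from compound 1 to compound 3 (0.80 log units; beyond the scatter), so the cost of this hydroxyl placement depends on the group elsewhere in the molecule. Compound 3 is known only as a limit of the assay: the limit of > 50000 nM in this assay, at which 1 of the 3 values shown sits.

On these data alone, how far compound 3 lies past that limit stays open. So does whether an amine in place of the hydroxyl on this ring would behave like 2-hydroxyphenyl.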